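The source may hold more compounds than are shown below. What is called first, only, known or untested is meant among the compounds shown, and "the series" means these compounds.

Three compounds sharing one core were tested in a functional assay on WM 266-4 cells (Homo sapiens) for inhibition, read by MTT assay, with a stated time of 24 h; a lower number here means a stronger inhibitor of growth, a higher number a weaker inhibitor of growth. Compound 1 `O=C(C1COc2ccccc2O1)N1N=C(c2ccc(Br)cc2)CC1c1ccccc1F` gives 8030 nM, compound 2 `O=C(C1COc2ccccc2O1)N1N=C(c2ccc(Br)cc2)CC1c1cccc(F)c1` gives 7810 nM, and compound 3 `O=C(C1COc2ccccc2O1)N1N=C(c2ccccc2)CC1c1cccc(F)c1` gives 1450 nM. Compound 2 thus holds the second highest of the three numbers; its nearest neighbour is compound 1, with a 1.0-fold lower number from compound 1 to compound 2 (0.01 log units; within the scatter), so the two cannot be told apart, while compound 3 lies furthest away, with a 5.4-fold lower number from compound 2 to compound 3 (0.73 log units; beyond the scatter).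

The unmeasured compound 4 `O=C(c1ccc2c(c1)OCCO2)N1N=C(c2ccc(Br)cc2)CC1c1cccc(F)c1` is built from the same atoms as compound 2, joined differently: 2,3-dihydro-1,4-benzodioxin-6-yl in place of 2,3-dihydro-1,4-benzodioxin-2-yl on a carbonyl carbon. Neither measured step bears on a change of this kind. The step from compound 1 to compound 2 shifted a fluorine on a phenyl ring and stayed within the scatter; the step from compound 2 to compound 3 replaced a bromo on an aromatic carbon with hydrogen and gave a modest drop in the number. The change to compound 4 touches neither of those groups, so there is no measured guide to its size or direction.

Compound 4 is therefore expected to land near compound 2, estimated at 7500 nM with a range from 2500 nM to 25000 nM. That estimate means an expected 1.0-fold lower number from compound 2 to compound 4 (0.02 log units; within the scatter), no step beyond the scatter, though the range is kept wide for want of any precedent.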

Compound 4, concentration for 50% growth inhibition: 810 nM
Compound 4: the middle estimate sits 9.3-fold (0.97 log units) above what was measured; measured number outside the range, below it.
By their numbers in this assay, from the lowest: compounds 4 and 3 (each within the scatter of the next); then compounds 2 and 1 (each within the scatter of the next).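

Changing only how the 2,3-dihydro-1,4-benzodioxin unit is joined to the carbonyl carbon, with no atom added or lost, gives a 9.6-fold lower number from compound 2 to compound 4 (0.98 log units; beyond the scatter) in this assay for growth inhibition. Going by these compounds alone, the two groups have the same heavy-atom, hydrogen-bond donor and hydrogen-bond acceptor counts, so this position responds to how the atoms are connected, not only to which atoms are present, something the earlier steps at the fluorine and the bromo group could not show. Nothing available explains why the 2,3-dihydro-1,4-benzodioxin-6-yl group gives the lower number.

On these data alone, it remains open whether the same change would give a similar step in a compound carrying hydrogen in place of the bromo, as compound 3 does, or with the fluorine placed as in compound 1. As far as these compounds go, it is also open how the number would respond to other groups on this carbonyl carbon, such as a pyridine ring or a phenyl ring carrying a methoxy group, and so whether the benzodioxin unit itself is needed.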